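Aryl swap on the triazole carbon: compound 3 to compound 4

A few compounds are considered here, and "the series" means these few. Any claim that something is new, unique, unknown or untested is made for them only; others in the source may bear on it.

The series shares a hydroxamic acid core and varies the aryl group on the triazole. Compound 1 `O=C(NO)c1ccc(NCc2nc(-c3ccc(Br)o3)nn2-c2ccccc2)cc1` gives 55.8% in an assay on Sf9 cells for inhibition of protein deacetylase HDAC6 (Homo sapiens), read by fluorescence, with a stated time of 40 min, tested at 100 nM; on this read-out lower numbers stand for less inhibition and higher numbers for more inhibition at the one concentration tested (going by the name of the read-out). Compound 2 `O=C(NO)c1ccc(NCc2nc(-c3cccc4cnccc34)nn2-c2ccccc2)cc1` gives 40.2%, and compound 3 `O=C(NO)c1ccc(NCc2nc(-c3ccc(Br)cc3)nn2-c2ccccc2)cc1` gives 54.7%. Compound 3 stands second highest of the three; its nearest neighbour is compound 1, as the step of a number 1.1 percentage points lower from compound 1 to compound 3 (within the scatter) lies within the scatter, and its furthest is compound 2, with a number 14.5 percentage points higher from compound 2 to compound 3 (beyond the scatter) beyond the scatter.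

Compound 4 `O=C(NO)c1ccc(NCc2nc(-c3cccnc3)nn2-c2ccccc2)cc1` differs from compound 3 in one place: pyridin-3-yl in place of 4-bromophenyl on an aromatic carbon.

Among the measured compounds shown here, the steps that bear on this change are those at the same aromatic carbon. Swapping 5-bromofuran-2-yl for 4-bromophenyl gave a number 1.1 percentage points lower from compound 1 to compound 3 (within the scatter), no real movement. The only departure from a ring of carbon only, isoquinolin-5-yl in compound 2, gave a number 15.6 percentage points lower from compound 1 to compound 2 (beyond the scatter) and a number 14.5 percentage points higher from compound 2 to compound 3 (beyond the scatter), both modest and beyond the scatter. Pyridin-3-yl brings a ring with one hetero atom and one hydrogen-bond acceptor, so a modest decrease is expected, estimated as a number 9.7 percentage points lower from compound 3 to compound 4 (within the scatter). Compound 4 is therefore expected to give 45%, with a range from 25% to 62%.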

Compound 4, a percentage reported as inhibition, at one concentration (the size of the read-out at that concentration, not a potency): 57.7%
Estimate against measurement, compound 4: 12.7 percentage points below, within the range that was stated.
By their numbers in this assay, from the lowest: compound 2; then compounds 3, 1 and 4 (each within the scatter of the next).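

At this aromatic carbon, between two ring nitrogen atoms, pyridin-3-yl leaves the number level in this assay: neither a number 3 percentage points higher from compound 3 to compound 4 (within the scatter) nor a number 1.9 percentage points higher from compound 1 to compound 4 (within the scatter) separates the compounds, so the bromine carried by compounds 1 and 3 is not needed to hold the read-out at this level. Among the compounds shown here, a ring nitrogen at this carbon therefore does not by itself go with a lower number: compound 2 is the one compound that goes against the otherwise flat picture, and a number 17.5 percentage points higher from compound 2 to compound 4 (beyond the scatter) shows that the isoquinolin-5-yl result does not carry over to the smaller pyridin-3-yl ring. No measured evidence on these compounds accounts for compound 2 standing apart from the other three.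

The compounds shown leave open whether the position accepts pyridin-4-yl or pyridin-2-yl, an aminomethyl group, a carboxylic acid or a longer alkyl chain in place of the aryl ring. They also leave open whether compounds 1, 3 and 4, which a single-concentration read-out does not separate, would stay together across a full concentration series.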